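From cyclohexylamino to 4-methylpiperazin-1-yl on the shared core

The compounds below may be only part of what the source reports. "The series", "measured", "known", "first", "only" and "open" are said of these compounds alone.

Compound 3 (`O=C(CCC(=O)c1cccc(C(F)(F)F)c1)NC1CCCCC1`) gives > 200 mg/kg in a functional assay on the whole organism with Mus musculus as the target (a lower number here means that less compound is needed, a higher number that more compound is needed for the effect), and this is a limit. Compound 2 (`CC(C)CNC(=O)CCC(=O)c1cccc(C(F)(F)F)c1`) gives > 200 mg/kg in this assay and this too is a limit. Compound 1 (`CN(C)C(=O)CCC(=O)c1cccc(C(F)(F)F)c1`) gives > 50 mg/kg in this assay and this is also a limit.

Compound 4 (`CN1CCN(C(=O)CCC(=O)c2cccc(C(F)(F)F)c2)CC1`) carries 4-methylpiperazin-1-yl in place of cyclohexylamino on a carbonyl carbon. The measured steps offer no size to carry over: the series shows a step that the two limits leave unreadable from compound 1 to compound 3 and also a step that the two limits leave unreadable from compound 2 to compound 3 and finally a step that the two limits leave unreadable from compound 1 to compound 2 as its third step. Compound 4 has no amide hydrogen, as in compound 1 and unlike compound 2 and compound 3, but the limits do not show whether that matters.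

Any expectation is therefore weak, and a further limit is quite possible. The expected change is an at least 1.6-fold lower number from compound 3 to compound 4 (0.22 log units; that floor lies within the scatter) in size, tentatively toward less compound needed. For compound 4 the estimate is 120 mg/kg with an expected range from 40 mg/kg to 350 mg/kg in this series.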

Compound 4, dose for half-maximal effect: > 50 mg/kg
Compound 4: only a limit was reported; the forecaster's own chance of this, stated with the estimate: 60%; the middle value is on the limit's open side.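

The steps from compound 1, compound 2 and compound 3 to compound 4 cannot be read: all four compounds stand only as limits in this assay. The compounds shown leave open what dose any of them needs, and whether the amide hydrogen, absent from compound 1 and compound 4, matters.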